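The source may report more compounds than this note shows. Statements on the series, on what has been measured and on what is new or still open speak of the compounds shown alone.

Measured so far in a functional assay on KB cells (Homo sapiens) for antiproliferative activity, read by sulforhodamine B assay, with a stated time of 3 days; on this read-out higher numbers stand for an effect only at larger amounts of compound and lower numbers for an effect already at smaller amounts:
- compound 1 `CCC1=C(O)c2c(oc(-c3ccc(OC(F)(F)F)cc3)cc2=O)C(CC)(CC)C1=O`: 36.5 uM
- compound 2 `CCC1=C(O)c2c(oc(-c3ccc(F)cc3)cc2=O)C(CC)(CC)C1=O`: 33 uM

Compound 2 sits alongside compound 1 rather than apart from it: the step of a 1.1-fold lower number from compound 1 to compound 2 (0.04 log units; within the scatter) lies within the scatter, so the two numbers are not distinguished.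

Compound 3 `CCC1=C(O)c2c(oc(-c3cc(C)c(O)c(C)c3)cc2=O)C(CC)(CC)C1=O` differs from compound 2 by 4-hydroxy-3,5-dimethylphenyl in place of 4-fluorophenyl on an aromatic carbon. Among the measured compounds shown here, the only measured step, a 1.1-fold lower number from compound 1 to compound 2 (0.04 log units; within the scatter), exchanges one para substituent on the same aryl ring for another and moves nothing beyond the scatter. It bears on the present step only in part: the entering 4-hydroxy-3,5-dimethylphenyl brings a hydrogen-bond donor and acceptor that neither measured compound has, so no shown step covers that element. On the data shown, compound 3 is expected to stay near compound 2, with a 1.1-fold lower number from compound 2 to compound 3 (0.04 log units; within the scatter) not clearly beyond the scatter. The estimate for compound 3 in this assay is 30 uM, range 10 uM to 90 uM.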

Compound 3, concentration for half-maximal effect: 18.3 uM
Compound 3: the middle estimate sits 1.6-fold (0.21 log units) above what was measured; low and high end bracket the measured number.
By their numbers in this assay, from the lowest: compounds 3, 2 and 1 (each within the scatter of the next).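

In this assay, this aromatic carbon, next to the ring oxygen of the shared core, accepts a much larger exchange than the earlier pair covered: 4-hydroxy-3,5-dimethylphenyl in place of 4-fluorophenyl gives a 1.8-fold lower number from compound 2 to compound 3 (0.26 log units; within the scatter). A hydrogen-bond donor and acceptor, both absent from 4-fluorophenyl, therefore enter at this position without separating compound 3 from compound 2 on this read-out. No supporting measurement is available that would account for this result.

Still open, from the compounds shown here alone, is whether the hydroxy group or the methyl groups would, taken singly, leave the number in the same range, and whether an amine or a carboxylic acid on the aryl ring would do so too. The ethyl groups of the shared core are the same throughout, so the compounds shown say nothing about replacing them with longer chains.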